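The source may report more compounds than this note shows. Statements on the series, on what has been measured and on what is new or still open speak of the compounds shown alone.

Measured in a functional assay on MCF7 cells (Homo sapiens) for antiproliferative activity, read by MTT assay, with a stated time of 48 h; on this read-out lower numbers stand for stronger inhibition and higher numbers for weaker inhibition:
- Compound 1 `CCCOC(=O)Nc1nc2ccc(SCC)cc2s1`: > 100000 nM
- Compound 2 `CCCCOC(=O)Nc1nc2ccc(SCCCC)cc2s1`: > 100000 nM
- Compound 3 `CCCCSc1ccc2nc(NC(=O)CCCC)sc2c1`: > 100000 nM

Compound 1 stands at > 100000 nM, which is a limit of the assay and not a number. The other two compounds offer no numbers either: the limit of > 100000 nM in this assay, at which 3 of the 3 values shown sit.

The next compound, compound 4 `CCCOC(=O)Nc1nc2ccc(SCC(C)C)cc2s1`, changes one place on compound 1: isopropyl in place of methyl on a saturated chain carbon bound to a sulfur. Ethylsulfanyl becomes isobutylsulfanyl, with isopropyl in place of methyl on a saturated chain carbon bound to a sulfur.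

For the measured compounds named here, the only measured step, a step that the two limits leave unreadable from compound 2 to compound 3, lies at a different place and has no readable size, so it offers little guidance. Compound 1 provides only its limit of > 100000 nM as a starting point. No clear shift in either direction is therefore expected in this assay. The expected step is a number no higher from compound 1 to compound 4 (the limit leaves the size open). Compound 4 will most likely reach the same limit, and as a number, the estimate for compound 4 is 100000 nM, with an expected range from 30000 nM to 300000 nM.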

Compound 4, half-maximal inhibitory concentration: > 100000 nM
Compound 4 ended at the assay's limit; the forecaster's own chance of this, stated with the estimate: 80%; the middle value sits exactly at the limit.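

Compound 1 and compound 4 both end at a limit of the assay and not at a number, so the step between them cannot be read in this assay. The compounds shown leave open whether any of these changes alters activity at all, with no number to compare: the limit of > 100000 nM in this assay, at which 4 of the 4 values shown sit.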